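From bromo to trifluoromethoxy on the sulfonyl aryl

A few compounds are considered here, and "the series" means these few. Any claim that something is new, unique, unknown or untested is made for them only; others in the source may bear on it.

In a functional assay on the whole organism (strain Kunming) for inhibition, with Mus musculus as the target, with a stated time of 1 h, at a dose of 40 mg/kg by the oral route (a higher number here means more inhibition at the dose given (going by the name of the read-out), a lower number less inhibition), compound 3 `O=C(/C=C/c1ccccc1)c1ccc(N2CCN(S(=O)(=O)c3ccc(Br)cc3)CC2)cc1` gives 47.4%, the highest of the three numbers at hand. Compound 2 `O=C(/C=C/c1ccccc1)c1ccc(N2CCN(S(=O)(=O)c3ccc4ccccc4c3)CC2)cc1` gives 35%, and compound 1 `O=C(/C=C/c1ccccc1)c1ccc(N2CCN(c3ccc(Cl)c(Cl)c3)CC2)cc1` gives 13.4%. Both measured steps rise toward compound 3: a number 34 percentage points higher from compound 1 to compound 3 (beyond the scatter) and a number 12.4 percentage points higher from compound 2 to compound 3 (beyond the scatter). Compound 4 `O=C(/C=C/c1ccccc1)c1ccc(N2CCN(S(=O)(=O)c3ccc(OC(F)(F)F)cc3)CC2)cc1` differs from compound 3 by trifluoromethoxy in place of bromo on an aromatic carbon. Within the data shown here, only one measured step touches the aryl on the sulfonyl, and it exchanges the whole ring rather than one group on it, so the data give no direct guide to this change; the expected step of a number 5.4 percentage points lower from compound 3 to compound 4 (within the scatter) is therefore small, probably within the scatter, with a slight lean downward from the best-placed compound. Compound 4 is expected to give 42%, within the range 25% to 58%.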

Compound 4, a percentage reported as inhibition, in the whole organism at one dose (the size of the read-out at that dose, not a potency): 47.4%
Compound 4: middle estimate off by 5.4 percentage points, on the low side; the measured number falls inside the stated range.
By their numbers in this assay, from the lowest: compound 1; then compound 2; then compounds 3 and 4 (each within the scatter of the next).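

In this assay the exchange of bromo for trifluoromethoxy on the sulfonyl aryl gives no change at the digits printed from compound 3 to compound 4 (within the scatter) and so shows that this position accepts either group without a readable difference. Among these compounds, the edge over the naphthalen-2-yl compound, earlier seen only with bromo, also holds with trifluoromethoxy, as a number 12.4 percentage points higher from compound 2 to compound 4 (beyond the scatter) shows. No evidence is at hand to explain why the two groups read alike. The compounds shown leave open whether an amine or a carboxylic acid at this place would hold the same level. They also leave open how a phenyl carrying only hydrogen there would compare.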